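The source may report more compounds than this note shows. Statements on the series, on what has been measured and on what is new or still open speak of the compounds shown alone.

In a functional assay on HeLa cells (Homo sapiens) for inhibition, read by sulforhodamine B assay (a lower number here means a stronger inhibitor, a higher number a weaker inhibitor), compound 3 `CCOc1ccc(NC2=CC(=O)c3c(nc4n3[C@H]3OC[C@@H](O)[C@H]3OC4)C2=O)cc1` gives 14400 nM, making it the weakest of the three measured inhibitors. Compound 1 `O=C1C(Nc2ccc(I)cc2)=CC(=O)c2c1nc1n2[C@H]2OC[C@@H](O)[C@H]2OC1` gives 4010 nM, and compound 2 `Cc1ccc(NC2=CC(=O)c3c(nc4n3[C@H]3OC[C@@H](O)[C@H]3OC4)C2=O)cc1C` gives 4320 nM. Compound 4 `O=C1C(Nc2cccc(F)c2)=CC(=O)c2c1nc1n2[C@H]2OC[C@@H](O)[C@H]2OC1` changes the group on the amine nitrogen: 3-fluorophenyl in place of 4-ethoxyphenyl on an amine nitrogen. Going by the values given here, no measured compound carries 3-fluorophenyl, so the evidence is indirect. Two steps introduce the ethoxy group of compound 3: a 3.6-fold higher number from compound 1 to compound 3 (0.56 log units; beyond the scatter) and a 3.3-fold higher number from compound 2 to compound 3 (0.52 log units; beyond the scatter). Both are modest, so removing that group is expected to give a modest step toward a lower number, meaning a stronger inhibitor. The expected step is a 2.4-fold lower number from compound 3 to compound 4 (0.38 log units; beyond the scatter). For compound 4 the estimated value is 6000 nM, with an expected range from 2500 nM to 14000 nM.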

Compound 4, half-maximal inhibitory concentration: > 8000 nM
Compound 4 ended at the assay's limit; the forecaster's own chance of this, stated with the estimate: 2%; middle value at least 1.3-fold (0.12 log units) away from the limit.
By their numbers in this assay, from the lowest: compounds 1 and 2 (each within the scatter of the next); then compound 3.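

In this assay compound 4 reaches only a limit, > 8000 nM, and not a number. With 3-fluorophenyl on the amine nitrogen, the comparisons give an at least 1.8-fold higher number from compound 2 to compound 4 (0.26 log units; that floor lies within the scatter) and an at least 1.9-fold higher number from compound 1 to compound 4 (0.29 log units; that floor lies within the scatter), so this smaller group does not show a real loss, yet it also shows no match with the 4-iodophenyl or 3,4-dimethylphenyl groups. The step from compound 3 cannot be read, so no gain from losing the ethoxy group can be claimed, because compound 4 sits at the limit: the limit of > 8000 nM in this assay, at which 1 of the 4 values shown sits.

On these data alone, whether compound 4 truly differs from compound 3 stays open. So does how a phenyl ring carrying a carboxylic acid or an amine would behave on this nitrogen.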